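Compound 3 to compound 4: a dimethoxyphenyl swap

The source may hold more compounds than are shown below. What is called first, only, known or untested is meant among the compounds shown, and "the series" means these compounds.

Within the data shown here, in an ADME assay on cells (Lymphocyte, Homo sapiens) for cytotoxicity, read by MTT assay, with a stated time of 48 h (a higher number here means a weaker inhibitor, a lower number a stronger inhibitor), compound 3 (`COC(=O)/C(=C\c1ccc(OC(=O)c2ccc(OC)c(OC)c2)cc1)Sc1ccnc2cc(Cl)ccc12`) gives 51100 nM as the only number so far. Compound 1 (`COC(=O)/C(=C\c1ccc(OC(=O)c2cccc(OC)c2)cc1)Sc1ccnc2cc(Cl)ccc12`) reads > 100000 nM as a limit of the assay. Compound 2 (`COC(=O)/C(=C\c1ccc(OC(=O)c2ccccc2OC)cc1)Sc1ccnc2cc(Cl)ccc12`) reads > 100000 nM as a limit too. Compound 4 (`COC(=O)/C(=C\c1ccc(OC(=O)c2ccc(OC)cc2OC)cc1)Sc1ccnc2cc(Cl)ccc12`) has 2,4-dimethoxyphenyl in place of 3,4-dimethoxyphenyl on a carbonyl carbon. The measured steps bearing on this are an at least 1.9-fold lower number from compound 1 to compound 3 (0.29 log units; that floor lies within the scatter) and an at least 1.9-fold lower number from compound 2 to compound 3 (0.29 log units; that floor lies within the scatter) and neither shows a size beyond the scatter, while a step that the two limits leave unreadable from compound 1 to compound 2 gives no size. In this assay the expected change is a 1.3-fold higher number from compound 3 to compound 4 (0.10 log units; within the scatter) and so none beyond the scatter. For compound 4 the estimated value is 65000 nM with an expected range (30000 nM to 130000 nM).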

Compound 4, half-maximal inhibitory concentration: 41600 nM
Compound 4: the middle estimate sits 1.6-fold (0.19 log units) above what was measured, within the range that was stated.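

In this assay, 2,4-dimethoxyphenyl in place of 3,4-dimethoxyphenyl on the carbonyl carbon gives a 1.2-fold lower number from compound 3 to compound 4 (0.09 log units; within the scatter), so this change of methoxy pattern does not separate compound 3 and compound 4. Compound 4 also gives floors beyond the scatter against both compounds held at the limit, an at least 2.4-fold lower number from compound 2 to compound 4 (0.38 log units; beyond the scatter) and an at least 2.4-fold lower number from compound 1 to compound 4 (0.38 log units; beyond the scatter). An added methoxy can now be compared twice: the same change on two cores in this assay, an at least 1.9-fold lower number (0.29 log units; that floor lies within the scatter) from compound 1 to compound 3 and an at least 2.4-fold lower number (0.38 log units; beyond the scatter) from compound 2 to compound 4; the limit leaves it open whether they differ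

Compound 1 and compound 2 remain limits, so the step between them cannot be read. On these data alone, whether an amine or a carboxylic acid in place of a methoxy would shift the number in this assay remains open.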